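The source may report more compounds than this note shows. Statements on the series, on what has been measured and on what is new or still open speak of the compounds shown alone.

In a functional assay on cardiac atrium (Cavia porcellus) (on this read-out higher numbers stand for an effect only at larger amounts of compound and lower numbers for an effect already at smaller amounts), compound 2 `COC(=O)C1=C(C)NC(C)=C(C(=O)OC)C1c1c(-c2ccsc2)nc2sc(C)cn12` gives 2300 nM. That sits within the scatter of compound 1 `COC(=O)C1=C(C)NC(C)=C(C(=O)OC)C1c1c(-c2cccs2)nc2sccn12` at 1300 nM, and well short of compound 3 `COC(=O)C1=C(C)NC(C)=C(C(=O)OC)C1c1c(-c2ccncc2)nc2sc(C)cn12` at 7490 nM. Compound 4 `COC(=O)C1=C(C)NC(C)=C(C(=O)OC)C1c1c(-c2ccsc2)nc2sccn12` differs from compound 2 by hydrogen in place of methyl on an aromatic carbon, next to the ring sulfur. Among the measured compounds shown here, the only measured step, a 3.3-fold higher number from compound 2 to compound 3 (0.51 log units; beyond the scatter), is modest and concerns pyridin-4-yl in place of thiophen-3-yl, so it does not speak to the methyl. Compound 1, at 1300 nM, also lacks the methyl, though it carries thiophen-2-yl instead. No step beyond the scatter is therefore expected in this assay. The expected change is a 1.4-fold lower number from compound 2 to compound 4 (0.13 log units; within the scatter). Compound 4 is estimated at 1700 nM, within an expected range of 800 nM to 3600 nM.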

Compound 4, half-maximal effective concentration: 1060 nM
Estimate against measurement, compound 4: 1.6-fold (0.21 log units) above, and the stated range covers the measured number.
By their numbers in this assay, from the lowest: compounds 4, 1 and 2 (each within the scatter of the next, the first and the last beyond it); then compound 3.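

In this assay, among the compounds shown here, hydrogen in place of methyl on an aromatic carbon, next to the ring sulfur, gives (a 2.2-fold lower number from compound 2 to compound 4 (0.34 log units; beyond the scatter)), the first reading for this position, and it shows that the methyl changes the number only modestly. With the methyl gone, thiophen-3-yl in place of thiophen-2-yl gives (a 1.2-fold lower number from compound 1 to compound 4 (0.09 log units; within the scatter)), so the two thiophene attachments are not told apart here. Nothing measured on these compounds bears on this result. Open, as far as these compounds go, is whether an ethyl, a methoxy or a carboxylic acid at this position would move the number further. Also open, from the compounds shown here alone, is whether the methyl step holds with thiophen-2-yl or pyridin-4-yl on the core.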